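The source may report more compounds than this note shows. Statements on the series, on what has been measured and on what is new or still open speak of the compounds shown alone.

Working notes on the series, read in a functional assay on U-373MG ATCC cells for inhibition, with U373 MG (Homo sapiens) as the target, read by MTT assay, with a stated time of 7 days; a higher number here means a weaker inhibitor of growth, a lower number a stronger inhibitor of growth. Compound 1 `NC(=O)c1ncn2c(=O)n(Cc3ccccc3)nnc12` gives > 50000 nM, which is a limit of the assay and not a number. Compound 2 `COc1cccc(Cn2nnc3c(C(N)=O)ncn3c2=O)c1` gives > 50000 nM, also a limit. Both measured compounds therefore sit at the limit of > 50000 nM in this assay, at which 2 of the 2 values shown sit, so the position of compound 1 is known only as a limit.

Compound 3 `Cc1noc(Cn2nnc3c(C(N)=O)ncn3c2=O)n1` carries 3-methyl-1,2,4-oxadiazol-5-yl in place of the phenyl of compound 1, on a saturated chain carbon bound to an aromatic nitrogen: 3-methyl-1,2,4-oxadiazol-5-yl in place of phenyl on a saturated chain carbon bound to an aromatic nitrogen.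

Going by the values given here, the only measured step is a step that the two limits leave unreadable from compound 1 to compound 2, with methoxy in place of hydrogen on an aromatic carbon. Among the compounds with values here, it has no readable size, and it is a different change from the one in compound 3, so it gives only indirect guidance. Within the data shown here, with a step that the two limits leave unreadable from compound 1 to compound 2 as the sole precedent, no definite step is expected in this assay, and no direction can be assigned.

For compound 3 the expected value is 50000 nM, with an estimated range of 15000 nM to 100000 nM. The estimated step is a number no higher from compound 1 to compound 3 (the limit leaves the size open).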

Compound 3, concentration for 50% growth inhibition: > 50000 nM
Compound 3: only a limit was reported; the forecaster's own chance of this, stated with the estimate: 65%; the middle value lies on the limit itself.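

In this assay compound 3 gives > 50000 nM, which is a limit and not a number, so no step can be read between compound 1 and compound 3. All three compounds sit at the same place: the limit of > 50000 nM in this assay, at which 3 of the 3 values shown sit. The compounds shown leave open whether any change on the shared core shifts growth inhibition in this assay, and in which direction.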